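The source may hold more compounds than are shown below. What is called first, only, known or untested is meant among the compounds shown, and "the series" means these compounds.

Measured so far:
- compound 1, `COc1ccc(F)cc1CNCCCNc1ccnc2cc(C3CCCCC3)ccc12`: 2290 nM
- compound 2, `COc1ccc(F)cc1CNCCCNc1ccnc2cc(-c3ccc(C(C)(C)C)cc3)ccc12`: 620 nM

In an ADME assay on HepG2 cells (Homo sapiens) for cytotoxicity, read by luminescence, CellTiter-Glo and ATP content, with a stated time of 72 h (a higher number here means that more compound is needed for the effect, a lower number that less compound is needed), compound 2 holds the lowest of the two numbers; its nearest neighbour is compound 1, which gives 2290 nM in this assay. Going by the values given here, the single measured step, a 3.7-fold lower number from compound 1 to compound 2 (0.57 log units; beyond the scatter), shows that the position varied here moves the number beyond the scatter.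

Compound 3, `COc1ccc(F)cc1CNCCCNc1ccnc2cc(Oc3ccccc3OC)ccc12`, is not yet measured. It differs from compound 2 as follows: 2-methoxyphenoxy in place of 4-(tert-butyl)phenyl on an aromatic carbon. Among the compounds with values here, the one step in hand does not involve 2-methoxyphenoxy, so it gives no direct reading of the new change; it only shows the site is responsive. Within the data shown here, with no closer precedent, the working expectation is a number for compound 3 lying between compound 1 and compound 2, closer to the higher side, so the step of a 2.4-fold higher number from compound 2 to compound 3 (0.38 log units; beyond the scatter) is expected to be upward and probably beyond the scatter, though a result within the scatter of compound 2 cannot be excluded. The estimate for compound 3 in this assay is 1500 nM, with a range from 600 nM to 4000 nM.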

Compound 3, half-maximal effective concentration: 6400 nM
The estimate for compound 3 lay 4.3-fold (0.63 log units) below the measured number; the measured number lies above the stated range.
By their numbers in this assay, from the lowest: compound 2; then compound 1; then compound 3.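

In this assay, the position proves more responsive than the earlier step suggested: a 10-fold higher number from compound 2 to compound 3 (1.01 log units; beyond the scatter), and a 2.8-fold higher number from compound 1 to compound 3 (0.45 log units; beyond the scatter), so compound 3 has the highest number of the three. An aromatic ring in the substituent does not by itself keep the number low, since 4-(tert-butyl)phenyl and 2-methoxyphenoxy each carry one six-membered aromatic ring of carbon only, yet compound 3 runs against the lower number seen with compound 2. The change also replaces a group with 0 hydrogen-bond acceptors by one with 2, but no measurement shown explains the rise.

The three compounds do not separate the contribution of the methoxy group from that of the oxygen joining the ring to the core, a question that the plain phenoxy and 2-methoxyphenyl groups would address. Also open, as far as these compounds go, is how far the number moves with an amine or a carboxylic acid on this aromatic carbon, and whether a longer alkyl chain behaves more like cyclohexyl or 4-(tert-butyl)phenyl.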